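The source may hold more compounds than are shown below. What is called first, only, known or untested is meant among the compounds shown, and "the series" means these compounds.

Measured in a functional assay on HepG2 cells (Homo sapiens) for cytotoxicity, with a stated time of 72 h (a lower number here means that less compound is needed, a higher number that more compound is needed for the effect), each value a limit of the assay:

Compound 1 `C=C[C@@](C)(/C=C/c1ccc(O)cc1)CCC=O`: > 52000 nM.
Compound 2 `C=C[C@@](C)(/C=C/c1ccc(O)cc1)CC/C=C/C(=O)OCC`: > 52000 nM.
Compound 3 `C=C[C@@](C)(/C=C/c1ccc(O)cc1)CC/C=C/C#N`: > 52000 nM.

Compound 3 has no number, only the limit > 52000 nM. Within the data shown here, the series so far offers no firmer footing, with the limit of > 52000 nM in this assay, at which 3 of the 3 values shown sit.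

Compound 4 `C=C[C@@](C)(/C=C/c1ccc(O)cc1)CC/C=C(C)/C=N/N` has not yet been measured, and its difference from compound 3 is a group of 6 heavy atoms (4 carbon, 2 nitrogen; no ring) in place of a group of 4 heavy atoms (3 carbon, 1 nitrogen; no ring), on a saturated chain carbon, three bonds along the chain from two double-bonded chain carbons. The 2-cyanoethenyl is replaced on a saturated chain carbon, three bonds along the chain from two double-bonded chain carbons.

The measured changes at this same place are a step that the two limits leave unreadable from compound 1 to compound 2, a step that the two limits leave unreadable from compound 1 to compound 3 and a step that the two limits leave unreadable from compound 2 to compound 3. None of them has a size that can be read. Since a step that the two limits leave unreadable from compound 1 to compound 3 and a step that the two limits leave unreadable from compound 2 to compound 3 give no measure of what a change here does, no step beyond the scatter is expected in this assay, and no direction can be expected either.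

The estimated step is a step that the limit leaves unreadable from compound 3 to compound 4. Another limit is the most likely report, but a number cannot be ruled out. For compound 4 the expected value is 60000 nM, with an estimated range from 25000 nM to 140000 nM.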

Compound 4, half-maximal effective concentration: > 52000 nM
Compound 4 gave a limit, no number (the forecaster's own chance of this, stated with the estimate: 80%); the middle value does not contradict the limit.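

In this assay compound 4 gives only a limit, > 52000 nM. Its steps from compound 1, compound 2 and compound 3 therefore cannot be read. The compounds shown leave open whether any group at this place on the shared core would give a number in this assay, as the series so far holds only a limit: the limit of > 52000 nM in this assay, at which 4 of the 4 values shown sit.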